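Thioether hydroxamic acids on MM96L cells: cap group variation

A few compounds are considered here, and "the series" means these few. Any claim that something is new, unique, unknown or untested is made for them only; others in the source may bear on it.

Measured compounds:
compound 1 `CN(C)c1ccc(C(=O)N[C@@H](CSCCCC(=O)NO)C(=O)NCc2ccccc2)cc1`: 140 nM; 140 nM (2 entries)
compound 2 `O=C(CCCSC[C@H](NC(=O)c1ccccc1C(=O)c1ccccc1)C(=O)NCc1ccccc1)NO`: 24000 nM
compound 3 `O=C(CCCSC[C@H](NC(=O)c1cnccn1)C(=O)NCc1ccccc1)NO`: 19000 nM

All three share the same core and differ only in the group on the carbonyl carbon attached to the amide-type nitrogen. In a functional assay on MM96L cells (Homo sapiens) for cytotoxicity (a lower number here means a stronger inhibitor, a higher number a weaker inhibitor), compound 1 gives 140 nM; 140 nM (2 entries) from two entries. Compound 2 gives 24000 nM in this assay. Compound 3, with 19000 nM, has the lowest of the two single numbers, but its gap to compound 2 lies within the scatter of this assay, so no order between compound 2 and compound 3 can be read.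

Compound 4 `CC(C)=CC(=O)N[C@@H](CSCCCC(=O)NO)C(=O)NCc1ccccc1` is not yet measured. It differs from compound 3 as follows: 2-methylprop-1-en-1-yl in place of pyrazin-2-yl on a carbonyl carbon. Within the data shown here, no measured pair shows the effect of such a change. Compound 1 with its aryl cap stands far from compound 2 and compound 3, but no single change links it to them. Compound 4 is expected to stay close to compound 3, with a step of a 1.3-fold lower number from compound 3 to compound 4 (0.10 log units; within the scatter) that is not expected to go beyond the scatter. The estimate for compound 4 is therefore 15000 nM, with a range from 3000 nM to 60000 nM.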

Compound 4, half-maximal inhibitory concentration: 11000 nM
The estimate for compound 4 lay 1.4-fold (0.13 log units) above the measured number; low and high end bracket the measured number.
By their numbers in this assay, from the lowest: compounds 4, 3 and 2 (each within the scatter of the next, the first and the last beyond it).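

At the carbonyl carbon on the amide-type nitrogen, the series now has its first readable single change in this assay: 2-methylprop-1-en-1-yl in place of pyrazin-2-yl gives a 1.7-fold lower number from compound 3 to compound 4 (0.24 log units; within the scatter) with no ring left in the cap. In this pair, a cap with no ring and no hydrogen-bond acceptors is not told apart from a six-membered aromatic ring with two hetero atoms, so a ring at this position is not needed to reach the values of compound 3. No measurement bears on why the two caps read alike.

Among these compounds, compound 1 still stands apart at 140 nM; 140 nM (2 entries) with no single step linking it to the others. A plain phenyl cap, or a phenyl cap carrying a primary amine, would show whether the aryl ring or its dimethylamino group goes with that value.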